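This account rests on a few compounds, and the source may have more. Where it says the series, first, only, none or still open, it means among the compounds named here.

Measured in a functional assay on SK-BR-3 cells (Homo sapiens) for antiproliferative activity, read by XTT assay, with a stated time of 72 h; on this read-out higher numbers stand for weaker inhibition and lower numbers for stronger inhibition:
compound 1 `COc1ccc(-c2cc3ccccc3nc2/C=C/C(=O)c2ccc(F)cc2)cc1` gives 810 nM
compound 2 `COc1ccc(-c2cc3ccccc3nc2/C=C/C(=O)c2ccc[nH]2)cc1` gives > 10000 nM

Compound 2 shows only a limit of this assay, not a number. Its value is the limit of > 10000 nM in this assay, at which 1 of the 2 values shown sits. Going by the values given here, the one step measured so far, an at least 12-fold higher number from compound 1 to compound 2 (1.09 log units; beyond the scatter), runs from a 4-fluorophenyl on the carbonyl carbon to the pyrrolyl and ends at that limit.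

Compound 3 `COc1ccc(-c2cc3ccccc3nc2/C=C/C(=O)c2cnc(N)nc2C)cc1` differs from compound 2 by 2-amino-4-methylpyrimidin-5-yl in place of 1H-pyrrol-2-yl on a carbonyl carbon. Among the compounds with values here, no measured step covers this change directly. Within the data shown here, the only step that touches the group on the carbonyl carbon is an at least 12-fold higher number from compound 1 to compound 2 (1.09 log units; beyond the scatter), a large loss on leaving the 4-fluorophenyl; the entering group restores a six-membered aromatic ring, so a step back toward the number for compound 1 is expected, with its size left open as compound 2 provides only a limit. The expected step is an at least 3.3-fold lower number from compound 2 to compound 3 (0.52 log units; beyond the scatter). Compound 3 is estimated at 3000 nM, in the range 600 nM to 15000 nM.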

Compound 3, half-maximal inhibitory concentration: > 10000 nM
Compound 3 gave a limit, no number; the forecaster's own chance of this, stated with the estimate: 35%; middle value at least 3.3-fold (0.52 log units) from the limit.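

In this assay compound 3 gives > 10000 nM, which is a limit of the assay and not a number. Putting 2-amino-4-methylpyrimidin-5-yl in place of 4-fluorophenyl on the carbonyl carbon gives an at least 12-fold higher number from compound 1 to compound 3 (1.09 log units; beyond the scatter), so a six-membered aromatic ring on that carbon does not by itself hold the activity of compound 1. The step from compound 2 to compound 3 cannot be read, and the two groups stay unranked against each other: the limit of > 10000 nM in this assay, at which 2 of the 3 values shown sit.

Open, as far as these compounds go, is what in the 4-fluorophenyl carries the activity of compound 1, and whether a plain phenyl or a chlorophenyl on the carbonyl carbon would stay near it. Also open, from the compounds shown here alone, is whether a pyridinyl on that carbon, carrying neither the amino nor the methyl group, would read as a number rather than a limit.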